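A few compounds are considered here, and "the series" means these few. Any claim that something is new, unique, unknown or untested is made for them only; others in the source may bear on it.

Measured compounds in a physicochemical assay for lipophilicity; a higher number here means a more lipophilic compound, a lower number a more polar compound:
compound 1 `CC(C)Sc1nnc(-c2c(CNC3CC3)c3ccccc3n2C)n1-c1ccccc1`: 4.81
compound 2 `CC(C)Sc1nnc(-c2c(CNc3cnccn3)c3ccccc3n2C)n1-c1ccccc1`: 4.22

Compound 1 stands highest of the two numbers in this assay; its nearest neighbour is compound 2, with a number 0.59 log units lower from compound 1 to compound 2 (beyond the scatter).

Compound 3 `CC(C)Sc1nnc(-c2c(CNC3CC3)c3cc(F)ccc3n2C)n1-c1ccccc1` differs from compound 1 by fluoro in place of hydrogen on an aromatic carbon, a change that touches no amine nitrogen and so is unrelated to the step from compound 1 to compound 2. Within the data shown here, no measured pair covers it; that step gives only the scale of the series. The change is expected to bring a small shift, if any, and compound 3 is estimated at 4.95 (range 4.65 to 5.25), with a number 0.14 log units higher from compound 1 to compound 3 (within the scatter) expected, not beyond the scatter.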

Compound 3, partition coefficient: 4.97
Compound 3: middle estimate off by 0.02 log units, on the low side; the measured number falls inside the stated range.
By their numbers in this assay, from the lowest: compound 2; then compounds 1 and 3 (each within the scatter of the next).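

In this assay, fluoro in place of hydrogen on an aromatic carbon of the fused system gives a number 0.16 log units higher from compound 1 to compound 3 (within the scatter) and so does not separate the two compounds. Among these compounds, the earlier step concerned only the group on the amine nitrogen; this is the first reading of a change on the shared core, and it stays inside the scatter. Nothing on hand bears on the reason for this result.

From the compounds shown here alone, whether chloro or methoxy on this carbon would move the number beyond the scatter stays open. So does whether fluoro gives the same small step with pyrazin-2-yl on the amine nitrogen.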